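A few compounds are considered here, and "the series" means these few. Any claim that something is new, unique, unknown or untested is made for them only; others in the source may bear on it.

Compound 1 `COc1ccc([C@@H]2CC(=O)c3c(O)cc(OCc4cn(Cc5ccccc5F)nn4)cc3O2)cc1O` is one of three compounds sharing a core that have been measured in a functional assay on RAW264.7 cells (Mus musculus) for inhibition, read by Griess assay, with stated times of 2 h and 24 h; a lower number here means a stronger inhibitor, a higher number a weaker inhibitor; compound 1 gives 7320 nM. Compound 2 `COc1ccc([C@@H]2C/C(=N\O)c3c(O)cc(OCc4cn(C5CCCC5)nn4)cc3O2)cc1O` gives 6880 nM and compound 3 `COc1ccc([C@@H]2C/C(=N\O)c3c(O)cc(OCc4cn(Cc5ccccc5Cl)nn4)cc3O2)cc1O` gives 13400 nM in this assay, so compound 1 sits between the other two, and all three lie within the usual scatter of one another. Among the compounds with values here, the one change measured in a single place is a 1.9-fold higher number from compound 2 to compound 3 (0.29 log units; within the scatter). The new compound 4 `CCn1cc(COc2cc(O)c3c(c2)O[C@H](c2ccc(OC)c(O)c2)CC3=O)nn1` differs from compound 1 only at the group on the ring nitrogen: methyl in place of 2-fluorophenyl on a saturated chain carbon bound to an aromatic nitrogen. The step from compound 2 to compound 3 is the closest guide, since it also exchanges a small saturated group for a substituted benzyl on that nitrogen, and it stayed within the scatter. Compound 4 is therefore expected to give about 6000 nM in this assay, somewhere between 3000 nM and 13000 nM. This expectation amounts to a 1.2-fold lower number from compound 1 to compound 4 (0.09 log units; within the scatter), a shift no larger than the scatter.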

Compound 4, half-maximal inhibitory concentration: 15000 nM
Compound 4: middle estimate off by 2.5-fold (0.40 log units), on the low side, and the stated range ends below it.
By their numbers in this assay, from the lowest: compounds 2, 1, 3 and 4 (each within the scatter of the next, the first and the last beyond it).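

In this assay, the change from 2-fluorobenzyl to ethyl gives a 2.0-fold higher number from compound 1 to compound 4 (0.31 log units; beyond the scatter), so this position can shift the number beyond the scatter, though only modestly, which the earlier step at this nitrogen did not show. Here, the smaller group gives the higher number, meaning a weaker inhibitor, so on this core the 2-fluorophenyl is tolerated and cutting it back to methyl brings no gain. Nothing available explains why the step goes this way.

Going by these compounds, it remains open whether the fluorine or the aromatic ring accounts for the step, and a plain benzyl or a longer chain such as butyl would help separate the two. On these data alone, it is also open whether the same exchange would give a similar step on the core of compound 2.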